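Adding Fluoro to the Benzyl Group of Compound 3

The source may report more compounds than this note shows. Statements on the series, on what has been measured and on what is new or still open speak of the compounds shown alone.

Of the compounds shown here, three built on a shared core have been measured in a functional assay on HCT-116 cells (Homo sapiens) for antiproliferative activity, read by WST assay, with a stated time of 72 h; a lower number here means a stronger inhibitor of growth, a higher number a weaker inhibitor of growth. Compound 1 `N#Cc1ccc(CN[C@H]2[C@@H]3CN(c4ncc(C(=O)NO)cn4)C[C@@H]32)cc1` gives 270 nM, compound 2 `O=C(NO)c1cnc(N2C[C@@H]3[C@H](C2)[C@H]3NC(=O)c2ccccc2)nc1` gives 5100 nM, and compound 3 `O=C(NO)c1cnc(N2C[C@@H]3[C@H](C2)[C@H]3NCc2ccccc2)nc1` gives 120 nM, the lowest number of the three.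

The next compound is compound 4 `O=C(NO)c1cnc(N2C[C@@H]3[C@H](C2)[C@H]3NCc2ccc(F)cc2)nc1`. It differs from compound 3 in one place: fluoro in place of hydrogen on an aromatic carbon. In plain terms, this is fluoro in place of hydrogen on an aromatic carbon, para to a large group.

Two measured steps offer some guidance. The more relevant one also changes a group on an aromatic carbon: hydrogen in place of cyano gives a 2.3-fold lower number from compound 1 to compound 3 (0.35 log units; beyond the scatter), a modest step. The other, benzyl in place of benzoyl on an amine nitrogen, gives a 43-fold lower number from compound 2 to compound 3 (1.63 log units; beyond the scatter), a large step, but it is a different kind of change and says little about fluoro.

With only the modest cyano step as a guide, no clear change is expected in this assay, and no direction can be favoured. The estimated value for compound 4 is 110 nM, with an expected range from 50 nM to 240 nM. This estimate means a 1.1-fold lower number from compound 3 to compound 4 (0.04 log units; within the scatter), an expected step within the usual scatter.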

Compound 4, concentration for 50% growth inhibition: 380 nM
Compound 4: the middle estimate sits 3.5-fold (0.54 log units) below what was measured; the measured number lies above the stated range.
By their numbers in this assay, from the lowest: compound 3; then compounds 1 and 4 (each within the scatter of the next); then compound 2.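

In this assay, this place on the benzyl ring proves sensitive to a single added atom: there is a 3.2-fold higher number from compound 3 to compound 4 (0.50 log units; beyond the scatter) when fluoro replaces hydrogen, a modest step, though one beyond the scatter. Cyano and fluoro here cannot be told apart, with a 1.4-fold higher number from compound 1 to compound 4 (0.15 log units; within the scatter) inside the scatter, so both compounds carrying a group at this place stand above compound 3, which has only hydrogen there, and the earlier step with a 2.3-fold lower number from compound 1 to compound 3 (0.35 log units; beyond the scatter) no longer stands alone. The choice of link on the amine nitrogen still outweighs this ring change, since even with the fluoro in place there is a 13-fold lower number from compound 2 to compound 4 (1.13 log units; beyond the scatter) on going from benzoyl to 4-fluorobenzyl, a large step.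

Nothing shown explains why either group raises the number. On these data alone, with only hydrogen, fluoro and cyano at this place, it remains open whether a methyl group, a methoxy group, a chlorine atom or an amine would also raise the number, and whether fluoro would have the same effect elsewhere on the ring.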